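What an Added Chain May Do to Compound 2

This account rests on a few compounds, and the source may have more. Where it says the series, first, only, none or still open, it means among the compounds named here.

Compound 1 `CC(C)(C)C1=CC(=O)C=C(NCC(=O)O)C1=O`: 171000 nM
Compound 2 `CC1=CCC[C@H]2[C@](C)(CC3=CC(=O)C=CC3=O)[C@@H](C)CC[C@]12C`: 16700 nM

In a functional assay on MDA-MB-453 cells (Homo sapiens) for cytotoxicity, read by MTT assay, with a stated time of 72 h (on this read-out lower numbers stand for stronger inhibition and higher numbers for weaker inhibition), compound 2 gives the lower of the two numbers (16700 nM), and the gap to compound 1 (171000 nM) lies beyond the usual scatter. Compound 3 (`CC1=CCC[C@H]2[C@](C)(CC3=CC(=O)C=C(NCCC(=O)O)C3=O)[C@@H](C)CC[C@]12C`) differs from compound 2 in one place ((2-carboxyethyl)amino in place of hydrogen on a double-bonded ring carbon): (2-carboxyethyl)amino stands in place of hydrogen on a double-bonded ring carbon. Within the data shown here, no measured pair shows this change directly. Compound 1 (171000 nM) also carries a nitrogen-linked chain ending in a carboxylic acid and has the higher number, but its core is different, so this is only a weak hint. The expected step (a 1.5-fold higher number from compound 2 to compound 3 (0.18 log units; within the scatter)) is a modest rise in the number, meaning somewhat weaker inhibition. The estimate for compound 3 is (25000 nM), within an expected range (8000 nM to 80000 nM).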

Compound 3, half-maximal inhibitory concentration: 3310 nM
Compound 3: middle estimate off by 7.6-fold (0.88 log units), on the high side, outside the stated range (below it).
By their numbers in this assay, from the lowest: compound 3; then compound 2; then compound 1.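

In this assay, putting (2-carboxyethyl)amino in place of hydrogen on a double-bonded ring carbon gives a 5.0-fold lower number from compound 2 to compound 3 (0.70 log units; beyond the scatter), a step beyond the scatter. This position, two ring bonds from the ring atom that bears a large group, therefore tolerates a chain ending in a carboxylic acid, and on the shared core the number falls instead of rising, something compound 1, with its different core, could not show. Nothing available here explains why the number falls.

The compounds shown leave open whether the fall comes from the nitrogen link or from the carboxylic acid at the chain's end. A simple amine at this position, or a longer chain ending in the same acid, would help separate these two parts.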